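This account rests on a few compounds, and the source may have more. Where it says the series, first, only, none or still open, it means among the compounds named here.

In a functional assay on EKVX cells (Homo sapiens) for inhibition, read by sulforhodamine B assay, with a stated time of 48 h, tested at 10 uM (on this read-out lower numbers stand for less inhibition and higher numbers for more inhibition at the one concentration tested (going by the name of the read-out)), compound 1 `c1ccc2c(-c3cn4ccnc4c(-c4ccc5ncn(C6CCCCC6)c5c4)n3)cccc2c1` gives 13.3%, while compound 2 `c1ccc(Cn2cnc3ccc(-c4nc(-c5cccc6ccccc56)cn5ccnc45)cc32)cc1`, which carries benzyl in place of cyclohexyl on an aromatic nitrogen, gives 24.6%; this amounts to a number 11.3 percentage points higher from compound 1 to compound 2 (beyond the scatter). Compound 3 `c1cn2cc(-c3ccc4c(c3)ncn4C3CCCCC3)nc(-c3ccc4ncn(C5CCCCC5)c4c3)c2n1` gives 60.2% in this assay, the highest of the three numbers, though the difference between its core and the core of compound 1 is not broken down here. Compound 4 `c1ccc(Cn2cnc3ccc(-c4nc(-c5ccc6c(c5)ncn6C5CCCCC5)cn5ccnc45)cc32)cc1` has not yet been measured. It differs from compound 3 by benzyl in place of cyclohexyl on an aromatic nitrogen, the same change already seen from compound 1 to compound 2, with the place described in the same words. Within the data shown here, because compound 3 already stands at 60.2% and the earlier change gave a number 11.3 percentage points higher from compound 1 to compound 2 (beyond the scatter), the step from compound 3 to compound 4 is expected to be a number 7.8 percentage points higher from compound 3 to compound 4 (within the scatter), with a wide margin since only one precedent exists. Compound 4 is therefore estimated to give 68%, between 50% and 84%.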

Compound 4, a percentage reported as inhibition, at one concentration (the size of the read-out at that concentration, not a potency): -12.3%
For compound 4 the middle estimate is 80.3 percentage points above the measured one; the measured number lies below the stated range.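

In this assay, benzyl in place of cyclohexyl on an aromatic nitrogen gives a number 72.5 percentage points lower from compound 3 to compound 4 (beyond the scatter), so the change does not carry over from one core to the other with the same direction or size: the same change on two cores in this assay, a number 11.3 percentage points higher (beyond the scatter) from compound 1 to compound 2 and a number 72.5 percentage points lower (beyond the scatter) from compound 3 to compound 4, 83.8 percentage points apart, beyond the scatter of two such steps The result of this change therefore cannot be read from one of these two cores to the other. The two pairs do not show what sets the cores apart, and they give no rule for a third core.

The compounds shown leave open how a group other than cyclohexyl or benzyl on that aromatic nitrogen would behave on either core, such as a longer chain or a chain ending in an amine. They also leave open what a carboxylic acid on the benzyl ring would do.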